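Trimming the amide of compound 2 back to an amine

The source may hold more compounds than are shown below. What is called first, only, known or untested is meant among the compounds shown, and "the series" means these compounds.

Compound 2 (`COc1cc(/C=C/C(=O)c2cccc(NC(=O)c3ccco3)c2)ccc1O`) gives 82% in a functional assay on HUVEC cells (Homo sapiens) for inhibition, tested at 5 ug/mL (a higher number here means a stronger effect of the compound at the concentration tested, a lower number a weaker effect), the lowest of the two numbers in hand. Its nearest neighbour is compound 1 (`COc1cc(/C=C/C(=O)c2cccc(NC(=O)c3c(Cl)cccc3Cl)c2)ccc1O`), which in this assay gives 88%; the step of a number 6 percentage points lower from compound 1 to compound 2 (within the scatter) lies within the scatter, so the two compounds stand together rather than in any order.

Compound 3 (`COc1cc(/C=C/C(=O)c2cccc(N)c2)ccc1O`) has not yet been measured. It differs from compound 2 by hydrogen in place of (furan-2-yl)carbonyl on a nitrogen on an aromatic ring. Within the data shown here, the only measured step, a number 6 percentage points lower from compound 1 to compound 2 (within the scatter), exchanges one group on the carbonyl carbon for another while keeping the amide intact, and it was within the scatter. Among the measured compounds shown here, no measured step removes the (furan-2-yl)carbonyl altogether, so the data give no direct guide to how large a step in this assay this change will bring. The account therefore expects a loss for compound 3, but holds the range wide. Compound 3 is expected to give 55%, somewhere between 20% and 85%. The step of a number 27 percentage points lower from compound 2 to compound 3 (beyond the scatter) is estimated to be downward and beyond the scatter, though uncertain.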

Compound 3, a percentage reported as inhibition, at one concentration (the size of the read-out at that concentration, not a potency): 50%
For compound 3 the middle estimate is 5 percentage points above the measured one, and the stated range covers the measured number.
By their numbers in this assay, from the lowest: compound 3; then compounds 2 and 1 (each within the scatter of the next).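

In this assay taking the whole acyl group off the nitrogen on the aromatic ring brings a loss that the exchange on the carbonyl carbon did not bring, with a number 32 percentage points lower from compound 2 to compound 3 (beyond the scatter) and with a number 38 percentage points lower from compound 1 to compound 3 (beyond the scatter) as well. Furan-2-yl and 2,6-dichlorophenyl on the carbonyl carbon stood together within the scatter, whereas the free amino compound, compound 3, stands apart from both, so among these three compounds having an acyl group on this nitrogen matters more than which of the two it is. Nothing at hand accounts for this loss, and no measurement of any property of these compounds bears on it.

The compounds shown leave open whether the carbonyl alone restores the number or the ring on it also contributes, a question that a small acetyl group on the same nitrogen would address. They also leave open whether a urea or a sulfonamide in place of the amide would stand with compound 1 and compound 2 or with compound 3, and, with every reading taken at a single concentration, how these compounds would compare at other concentrations.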